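A Halogen Swap Tested for Cytotoxicity in Cells

A few compounds are considered here, and "the series" means these few. Any claim that something is new, unique, unknown or untested is made for them only; others in the source may bear on it.

Three compounds share one core. Compound 1 is `Cc1c(O)nc(SCC(=O)c2ccc(F)cc2)nc1Cc1cccc2ccccc12`, compound 2 is `Cc1c(O)nc(SCC(=O)c2ccc(Cl)cc2)nc1Cc1cccc2ccccc12` and compound 3 is `CCc1c(O)nc(SCC(=O)c2ccc(F)cc2)nc1Cc1cccc2ccccc12`. In a functional assay on MT4 cells (Homo sapiens) for cytotoxicity (on this read-out lower numbers stand for higher toxicity in this test and higher numbers for lower toxicity in this test), compound 1 gives >= 275000 nM, which is a limit of the assay and not a number. In this assay compound 2 gives >= 198000 nM, again a limit. In this assay compound 3 gives >= 240000 nM, also a limit. Compound 2 differs from compound 1 by chloro in place of fluoro on an aromatic carbon, and the step is a step that the two limits leave unreadable from compound 1 to compound 2. Compound 3 differs from compound 1 by methyl in place of hydrogen on a saturated chain carbon bound to an aromatic carbon, and that step is a step that the two limits leave unreadable from compound 1 to compound 3. Compound 4, `CCc1c(O)nc(SCC(=O)c2ccc(Cl)cc2)nc1Cc1cccc2ccccc12`, has not been measured; it differs from compound 3 by chloro in place of fluoro on an aromatic carbon, the same change as from compound 1 to compound 2. For compound 4 the expected step is an at least 1.0-fold lower number from compound 3 to compound 4 (0.01 log units; that floor lies within the scatter), resting on the earlier step being unreadable because compound 1 sits at the limit of >= 275000 nM in this assay, at which 1 of the 3 values shown sits, and compound 2 at the limit of >= 198000 nM in this assay, at which 1 of the 3 values shown sits. Compound 4 is estimated at 230000 nM, between 120000 nM and 400000 nM, most likely reported as a limit.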

Compound 4, half-maximal cytotoxic concentration: 56000 nM
The estimate for compound 4 lay 4.1-fold (0.61 log units) above the measured number; measured number below the stated range.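

In this assay, chloro in place of fluoro on the core of compound 3 gives an at least 4.2-fold lower number from compound 3 to compound 4 (0.63 log units; beyond the scatter), so on this core the change brings a readable drop, and the size printed is only a floor. With chloro held, methyl in place of hydrogen on the saturated chain carbon gives an at least 3.5-fold lower number from compound 2 to compound 4 (0.54 log units; beyond the scatter), so among these compounds only compound 4, which carries both changes, falls clear of the limits. The same halogen swap on the core of compound 1 cannot be read, nor can the methyl step with fluoro held, so the result does not show that the drop carries from one core to the other, because compound 1 sits at a limit of the assay and not a number: the limit of >= 275000 nM in this assay, at which 1 of the 4 values shown sits.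

The compounds shown leave open whether bromo or methoxy in the place of chloro would lower the number as well. They also leave open whether a longer chain in the place of the methyl-extended chain would go further.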